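Substituent variation on the shared core: compound 3 to compound 4

The source may report more compounds than this note shows. Statements on the series, on what has been measured and on what is new or still open speak of the compounds shown alone.

The shared core carries a substituent on an aromatic carbon that has so far been varied among the measured compounds. Compound 1 `C/C(=N\OCC(=O)O)c1ccc(C2CC2)cc1` bears a cyclopropyl group, and in a functional assay on the whole organism for inhibition, with Rattus norvegicus as the target, read by paw edema, with stated times of 1 h and 3 h, at a dose of 50 mg/kg by the oral route (a higher number here means more inhibition at the dose given (going by the name of the read-out), a lower number less inhibition), compound 1 gives < 20%, which is a limit of the assay and not a number. Compound 2 `C/C(=N\OCC(=O)O)c1ccc(C#N)cc1` bears a cyano group, and in this assay compound 2 gives < 20%, again a limit. Compound 3 `COc1ccc(/C(C)=N/OCC(=O)O)cc1` bears a methoxy group, and in this assay compound 3 gives < 20%, also a limit. Because (the limit of < 20% in this assay, at which 3 of the 3 values shown sit), the steps a step that the two limits leave unreadable from compound 1 to compound 2, a step that the two limits leave unreadable from compound 1 to compound 3 and a step that the two limits leave unreadable from compound 2 to compound 3 cannot be sized. Compound 3 therefore stands at the limit together with the other two compounds, with no number to rank it.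

Compound 4 `CSc1ccc(/C(C)=N/OCC(=O)O)cc1` differs from compound 3 by methylsulfanyl in place of methoxy on an aromatic carbon. Going by the values given here, no measured step bears directly on this change, and the three measured steps are all unreadable. The three measured compounds give no sign that any substituent on this aromatic carbon lifts the read-out past the limit. Compound 4 is therefore expected to stay near the same limit, with the step that the limit leaves unreadable from compound 3 to compound 4 estimated as no change beyond the scatter. The estimate for compound 4 in this assay is 12%, within the range 0% to 30%.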

Compound 4, a percentage reported as inhibition, in the whole organism at one dose (the size of the read-out at that dose, not a potency): < 20%
Compound 4 gave a limit, no number; the forecaster's own chance of this, stated with the estimate: 70%; the middle value lies beyond the limit too.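

In this assay compound 4 gives < 20% which is a limit of the assay and not a number. The steps linking compound 4 to compound 1, compound 2 and compound 3 therefore cannot be read, so no new step is gained: the limit of < 20% in this assay, at which 4 of the 4 values shown sit.

The compounds shown leave open whether any substituent on this aromatic carbon lifts the read-out past the limit, and how methylsulfanyl, methoxy, cyano and cyclopropyl rank against one another.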